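A few compounds are considered here, and "the series" means these few. Any claim that something is new, unique, unknown or untested is made for them only; others in the source may bear on it.

Measured so far:
- compound 1, `CCCCNc1nc(N)nc(C)c1CCCN1CCCCC1`: 133 nM
- compound 2, `CCCCNc1nc(N)nc(C)c1CCCC`: 780 nM

In an assay on HEK293 cells for agonist activity at Toll-like receptor 8 (Homo sapiens), read by spectrophotometry (on this read-out higher numbers stand for an effect only at larger amounts of compound and lower numbers for an effect already at smaller amounts), compound 2 gives 780 nM, the highest of the two numbers; its nearest neighbour is compound 1, which gives 133 nM. These two differ by one change, a 5.9-fold higher number from compound 1 to compound 2 (0.77 log units; beyond the scatter), which counts as a modest step beyond the scatter.

Compound 3, `CCCC#Cc1c(C)nc(N)nc1NCCCC`, is the next compound to be measured in this assay . It differs from compound 2 in one place: pent-1-yn-1-yl in place of butyl on an aromatic carbon. For the measured compounds named here, this change sits on the aromatic ring itself, not on the chain end where the one measured step took place. Going by the values given here, no measured pair shows what happens when the butyl on the aromatic carbon is exchanged for a pent-1-yn-1-yl, so the step from compound 1 to compound 2 does not bear directly on it.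

Among the compounds with values here, with no step to lean on, the expectation for compound 3 is a number close to that of compound 2, with the step of a 1.1-fold lower number from compound 2 to compound 3 (0.05 log units; within the scatter) expected to stay within the scatter. The estimate for compound 3 in this assay is 700 nM, with a range from 220 nM to 2200 nM.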

Compound 3, half-maximal effective concentration: 5000 nM
For compound 3 the middle estimate is 7.1-fold (0.85 log units) below the measured one, outside the stated range (above it).
By their numbers in this assay, from the lowest: compound 1; then compound 2; then compound 3.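

Swapping butyl for pent-1-yn-1-yl on this aromatic carbon of the shared core gives a 6.4-fold higher number from compound 2 to compound 3 (0.81 log units; beyond the scatter) in this assay, so compound 3 needs a larger amount to show an effect. The position therefore responds to the group it carries, even though both groups are all-carbon chains without a ring, hydrogen-bond donors or acceptors, or net charge. The entering group is slightly longer and holds a triple bond, but no measurement shown explains why the number rises or separates those two differences.

The compounds shown leave open whether pentyl, a saturated chain named for the same length as pent-1-yn-1-yl, would give a number closer to that of compound 2 or of compound 3, which would help separate chain length from the triple bond. They also leave open whether a shorter chain such as propyl would lower the number at this position, and whether a pent-1-yn-1-yl chain ending in an amine would follow the same direction as the piperidin-1-yl chain of compound 1.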